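The source may report more compounds than this note shows. Statements on the series, on what has been measured and on what is new or still open speak of the compounds shown alone.

Three compounds of this series share one core and a chain bearing a hydroxyl. Compound 1 `OC(CCn1nc2c(Br)c(Br)c(Br)c(Br)c2n1)c1cccc(Br)c1` carries a brominated aryl group on that chain; compound 2 `C[C@@H](O)CCn1nc2c(Br)c(Br)c(Br)c(Br)c2n1` and compound 3 `C[C@H](O)CCn1nc2c(Br)c(Br)c(Br)c(Br)c2n1` are the two drawn configurations of the methyl analogue. In a functional assay on MCF7 cells (Homo sapiens) for antiproliferative activity, read by MTT assay, with a stated time of 48 h, tested at 25 uM (on this read-out lower numbers stand for a stronger effect and higher numbers for a weaker effect at the one concentration tested), compound 1 gives 106%, compound 2 gives 77% and compound 3 gives 89%. Compound 3 thus stands second highest of the three numbers, nearest to compound 2 and furthest from compound 1. Among the measured compounds shown here, the only step measured between compounds differing in one place is a number 12 percentage points higher from compound 2 to compound 3 (beyond the scatter), and the two compounds are linked by the fact that compounds 2 and 3 differ only in the configuration as drawn. Compound 4 `CC(O)CCn1nc2c(Br)c(Br)c(Br)c(Br)c2n1` differs from compound 3 as follows: the two compounds have the same atoms and bonds; at least one stereo element is drawn with a configuration in one of them and without one in the other: 1 of 1 stereo elements differ; a stereocentre at a saturated chain carbon is drawn S in compound 3 and without a configuration in compound 4. The step from compound 2 to compound 3 is the one that bears on this change, and it was modest, so the undrawn configuration of compound 4 should give a number between the two drawn ones. On that basis the step expected for compound 4 is a number 6 percentage points lower from compound 3 to compound 4 (within the scatter), within the scatter. Compound 4 is estimated at 83%, with a range from 72% to 95%.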

Compound 4, a percentage reported as activity, at one concentration (the size of the read-out at that concentration, not a potency): 73%
The estimate for compound 4 lay 10 percentage points above the measured number; the range from low to high includes it.
By their numbers in this assay, from the lowest: compounds 4 and 2 (each within the scatter of the next); then compound 3; then compound 1.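

At the carbon bearing the hydroxyl, the form drawn without a configuration takes no middle place in this assay: it sits with the R-drawn compound 2 (a number 4 percentage points lower from compound 2 to compound 4 (within the scatter)) and apart from the S-drawn compound 3 (a number 16 percentage points lower from compound 3 to compound 4 (beyond the scatter)). Among the three methyl analogues, only the S drawing therefore stands apart, in the direction of a weaker effect. At the same carbon, methyl in place of 3-bromophenyl gives a large step (a number 33 percentage points lower from compound 1 to compound 4 (beyond the scatter)), larger than either step in configuration alone.

How much of each configuration compound 4 holds is not stated, so its number cannot be read as a blend of the other two. Going by these compounds, whether an ethyl group, an unsubstituted phenyl or a longer chain at this carbon, or an amine in place of the hydroxyl, would shift the number remains open.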